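The source may report more compounds than this note shows. Statements on the series, on what has been measured and on what is new or still open speak of the compounds shown alone.

Measured in an ADME assay (liver) for metabolic stability, with Liver microsome (Homo sapiens) as the target, read by LC-MS, using microsomes, with a stated time of 30 min, tested at 4 uM; on this read-out higher numbers stand for a more stable compound and lower numbers for a less stable compound:
- Compound 1 `CC(=O)NCCn1c(-c2ccccc2Cl)nc2c(N3CCN(C)CC3)nc(C)nc21`: 0%
- Compound 2 `Cc1nc(N2CCN(C)CC2)c2nc(-c3cccc(Cl)c3)n(C3CCOCC3)c2n1`: 25%
- Compound 3 `Cc1nc(N2CCN(C)CC2)c2nc(-c3ccccc3C(F)(F)F)n(C3CCOCC3)c2n1`: 24%

Compound 3, at 24%, sits level with compound 2, at 25%, within the scatter. Compound 1, at 0%, lies lower, beyond the scatter.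

Compound 4 `Cc1nc(N2CCN(C)CC2)c2nc(-c3cccc(C(F)(F)F)c3)n(C3CCOCC3)c2n1` has the same atoms as compound 3, joined differently: 3-(trifluoromethyl)phenyl in place of 2-(trifluoromethyl)phenyl on an aromatic carbon. For the measured compounds named here, the one measured step that bears on this swap is a number 1 percentage points lower from compound 2 to compound 3 (within the scatter), which put 2-(trifluoromethyl)phenyl in place of 3-chlorophenyl. That step is small, so no change beyond the scatter is expected, only a number 1 percentage points higher from compound 3 to compound 4 (within the scatter). Compound 4 is estimated at 25%, with an expected range from 12% to 40%.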

Compound 4, percent of the compound remaining: 19%
The estimate for compound 4 lay 6 percentage points above the measured number; low and high end bracket the measured number.
By their numbers in this assay, from the lowest: compound 1; then compounds 4, 3 and 2 (each within the scatter of the next).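

In this assay, 3-(trifluoromethyl)phenyl in place of 2-(trifluoromethyl)phenyl gives a number 5 percentage points lower from compound 3 to compound 4 (within the scatter), and trifluoromethyl in place of chloro gives a number 6 percentage points lower from compound 2 to compound 4 (within the scatter). Neither the change of trifluoromethyl placement on the phenyl ring nor this exchange of chloro for trifluoromethyl separates these compounds on this read-out. Nothing available explains these numbers. Still open, on these data alone, is how the read-out responds to a carboxylic acid or an amine on this phenyl ring, in place of trifluoromethyl. As far as these compounds go, a methoxy group there is equally open.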